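Amide to ester on the carbonyl of compound 2

The compounds below may be only part of what the source reports. "The series", "measured", "known", "first", "only" and "open" are said of these compounds alone.

Measured so far:
compound 1 `CCn1c(C(=O)Nc2ccc(OC(F)(F)F)cc2)ccc1C(CC)(CC)c1ccc(OCC(O)C(C)(C)C)c(C)c1`: > 50000 nM
compound 2 `CCOc1ccc(NC(=O)c2ccc(C(CC)(CC)c3ccc(OCC(O)C(C)(C)C)c(C)c3)n2CC)cc1`: 630 nM

Within the data shown here, in an assay on HL-60 cells for agonist activity at vitamin D3 receptor (Homo sapiens), read by microscopy, with a stated time of 96 h (a lower number here means that less compound is needed, a higher number that more compound is needed for the effect), compound 2 holds the only number; the other entry is a limit. For compound 1 the value is the limit (the limit of > 50000 nM in this assay, at which 1 of the 2 values shown sits). Among the measured compounds shown here, the one measured step, an at least 79-fold lower number from compound 1 to compound 2 (1.89 log units; beyond the scatter), concerns the group on the aromatic oxygen and leaves the carbonyl untouched. Compound 3 `CCOC(=O)c1ccc(OC(=O)c2ccc(C(CC)(CC)c3ccc(OCC(O)C(C)(C)C)c(C)c3)n2CC)cc1` differs from compound 2 by 4-(ethoxycarbonyl)phenoxy in place of (4-ethoxyphenyl)amino on a carbonyl carbon. For the measured compounds named here, no measured step bears on this change, so the expectation rests on the structure alone. The expected step is a 4.0-fold higher number from compound 2 to compound 3 (0.60 log units; beyond the scatter). Compound 3 is estimated at 2500 nM, between 300 nM and 30000 nM.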

Compound 3, half-maximal effective concentration: > 50000 nM
Compound 3: only a limit was reported; the forecaster's own chance of this, stated with the estimate: 25%; at least 20-fold (1.30 log units) between middle value and limit.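

In this assay the change on the carbonyl carbon gives an at least 79-fold higher number from compound 2 to compound 3 (1.89 log units; beyond the scatter), so this position, untouched by the earlier step, does not accept 4-(ethoxycarbonyl)phenoxy in place of (4-ethoxyphenyl)amino without a large loss. The step from compound 1 to compound 3 cannot be read, as both values are limits of the assay: the limit of > 50000 nM in this assay, at which 2 of the 3 values shown sit.

The replacement alters the atom on the carbonyl carbon and the group on the aromatic ring together, and the compounds shown do not separate the two. Open, on these data alone, is how 4-ethoxyphenoxy or (4-(ethoxycarbonyl)phenyl)amino on the carbonyl carbon would read out.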